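The compounds below may be only part of what the source reports. "The series", "measured", "known", "first", "only" and "open" are said of these compounds alone.

Measured so far in a functional assay on MCF7 cells (Homo sapiens) for antiproliferative activity, read by MTT assay, with a stated time of 72 h; on this read-out higher numbers stand for weaker inhibition and lower numbers for stronger inhibition:
compound 1 `COc1cc2ncnc(N3CCc4ccccc43)c2cc1NC(=O)C=C(C)C` gives 6390 nM
compound 2 `C/C=C/C(=O)Nc1cc2c(N3CCc4ccccc43)ncnc2cc1OC` gives 4030 nM
compound 3 `COc1cc2ncnc(N3CCCc4ccccc43)c2cc1NC(=O)C=C(C)C` gives 6870 nM

Compound 1 and compound 2 differ by prop-1-en-1-yl in place of 2-methylprop-1-en-1-yl on a carbonyl carbon; this step gives a 1.6-fold lower number from compound 1 to compound 2 (0.20 log units; within the scatter). The difference between the core of compound 1 and the core of compound 3 is not broken down here. Compound 4 `C/C=C/C(=O)Nc1cc2c(N3CCCc4ccccc43)ncnc2cc1OC` has not been measured in this assay. It differs from compound 3 by prop-1-en-1-yl in place of 2-methylprop-1-en-1-yl on a carbonyl carbon, the same change as between compound 1 and compound 2, at the same place. Going by the values given here, the expected step from compound 3 to compound 4 is a 1.6-fold lower number from compound 3 to compound 4 (0.19 log units; within the scatter), set beside the measured one because a 1.6-fold lower number from compound 1 to compound 2 (0.20 log units; within the scatter) is the only guide available. Compound 4 is therefore estimated at 4400 nM in this assay, with a range from 2200 nM to 8800 nM.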

Compound 4, half-maximal inhibitory concentration: 12700 nM
Compound 4: the middle estimate sits 2.9-fold (0.46 log units) below what was measured; the measured number lies above the stated range.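

In this assay, prop-1-en-1-yl in place of 2-methylprop-1-en-1-yl on a carbonyl carbon gives a 1.8-fold higher number from compound 3 to compound 4 (0.27 log units; within the scatter). Each step taken alone stays within the scatter, but the two steps differ, so this change does not carry over unaltered from one core to the other: the same change on two cores in this assay, a 1.6-fold lower number (0.20 log units; within the scatter) from compound 1 to compound 2 and a 1.8-fold higher number (0.27 log units; within the scatter) from compound 3 to compound 4, 2.9-fold (0.47 log units) apart, beyond the scatter of two such steps. This rests on a single pair of steps and shows neither why the steps differ nor how the change would behave on any other core.

Still open, from the compounds shown here alone, is how a longer chain ending in an amine, in place of either group on the carbonyl carbon, would read on these two cores. Also open, going by these compounds, is which of the two steps a further core would follow.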